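The source may report more compounds than this note shows. Statements on the series, on what has been measured and on what is new or still open speak of the compounds shown alone.

Measured compounds:
compound 1 `O=C(Nc1ccc(Cl)c(C(=O)Nc2ccc(-c3ncc[nH]3)nc2)c1)c1ccc(Cl)c(Cl)c1`, 9390 nM
compound 2 `O=C(Nc1ccc(Cl)c(Cl)c1)c1ccc(Cl)c(C(=O)Nc2ccc(-c3ncc[nH]3)nc2)c1`, "not determined" (no result reported)

Among the measured compounds shown here, in a functional assay on A-375 cells (Homo sapiens) for cytotoxicity, read by MTT assay, with a stated time of 72 h (on this read-out lower numbers stand for stronger inhibition and higher numbers for weaker inhibition), compound 1 gives 9390 nM, the only number in this set; for compound 2 the entry reads "not determined" (no result reported), so compound 1 stands alone and no step between measured compounds exists. Compound 3 `Cc1cc(C(=O)Nc2ccc(Cl)c(C(=O)Nc3ccc(-c4ncc[nH]4)nc3)c2)ccc1Cl` differs from compound 1 by methyl in place of chloro on an aromatic carbon. For the measured compounds named here, with no measured step to lean on, the expected step of a 1.1-fold higher number from compound 1 to compound 3 (0.03 log units; within the scatter) is small, of no clear direction, and not beyond the usual scatter. Compound 3 is therefore estimated at 10000 nM, with a range from 3000 nM to 32000 nM.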

Compound 3, half-maximal inhibitory concentration: 12600 nM
Compound 3: the middle estimate sits 1.3-fold (0.10 log units) below what was measured, within the range that was stated.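

In this assay, among the compounds shown here, the change from 3,4-dichlorophenyl to 4-chloro-3-methylphenyl gives a 1.3-fold higher number from compound 1 to compound 3 (0.13 log units; within the scatter), the first step that can be read. At this position, ortho to a chloro group and meta to a large group, this read-out does not separate methyl from chloro. Nothing measured here bears on the reason for this. From the compounds shown here alone, whether an amine, a carboxylic acid or a longer chain at this position would also stay within the scatter remains open. Also open, going by these compounds, is whether the same methyl-for-chloro change would read the same way on another aromatic carbon of the series.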